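The compounds below may be only part of what the source reports. "The series", "measured", "known", "first", "only" and "open" are said of these compounds alone.

Among the compounds with values here, compound 1 `CCc1cccc(NC(=O)N[C@H](C)c2ccccc2)c1` gives 36% in an ADME assay on the whole organism with Oryza sativa as the target, tested at 10 uM (on this read-out lower numbers stand for a stronger effect and higher numbers for a weaker effect at the one concentration tested), the lower of the two numbers measured so far. Its configurational partner, compound 2 `CCc1cccc(NC(=O)N[C@@H](C)c2ccccc2)c1`, gives 86%, a step of a number 50 percentage points higher from compound 1 to compound 2 (beyond the scatter) that rests on (the fact that compounds 1 and 2 differ only in the configuration as drawn). Compound 3 `C[C@@H](NC(=O)Nc1cccc(Br)c1)c1ccccc1` is not yet measured; it differs from compound 1 by bromo in place of ethyl on an aromatic carbon. Within the data shown here, no measured step involves such an exchange at this position, so the only anchor is the value of compound 1 itself, and no step beyond the scatter is expected in this assay. Compound 3 is therefore estimated at 40%, between 20% and 65%, a step of a number 4 percentage points higher from compound 1 to compound 3 (within the scatter).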

Compound 3, a percentage reported as activity, at one concentration (the size of the read-out at that concentration, not a potency): 99%
The estimate for compound 3 lay 59 percentage points below the measured number; the measured number lies above the stated range.
By their numbers in this assay, from the lowest: compound 1; then compound 2; then compound 3.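

The aromatic carbon meta to a large group is not a silent position: with bromo in place of ethyl in this assay, the result is a number 63 percentage points higher from compound 1 to compound 3 (beyond the scatter). The earlier compounds shown here showed sensitivity only to configuration at the saturated chain carbon, whereas this exchange shows that the effect also depends on the group on the aromatic ring. No available evidence bears on the reason for this step.

Still open, from the compounds shown here alone, is whether the step follows from the loss of ethyl or the entry of bromo, since a methyl, a longer chain, an amine or a carboxylic acid at this carbon would separate the two. Also open, going by these compounds, is how the opposite configuration behaves with bromo on the ring.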